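The compounds below may be only part of what the source reports. "The series", "measured", "known", "first", "only" and "open" are said of these compounds alone.

Working notes on the series. Compound 1 `COc1ccc(C(=O)c2cc(C)ccc2OCC(=O)NNC(=O)c2cc3ccccc3oc2=O)cc1` is measured in a functional assay on Ehrlich cells (Mus musculus) for cytotoxicity, read by MTT assay, with a stated time of 48 h (a higher number here means a weaker inhibitor, a lower number a stronger inhibitor), where compound 1 gives 38400 nM. Compound 2 `Cc1ccc(OCC(=O)NNC(=O)c2cc3ccccc3oc2=O)c(C(=O)c2ccccc2)c1` differs from compound 1 by hydrogen in place of methoxy on an aromatic carbon, and in this assay compound 2 gives 78400 nM. Among the measured compounds shown here, the single measured step, a 2.0-fold higher number from compound 1 to compound 2 (0.31 log units; beyond the scatter), is modest but beyond the scatter. For the measured compounds named here, compound 2 therefore stands at the highest of the two numbers so far, with compound 1 the nearest at a lower number.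

Compound 3 `Cc1ccc(OCC(=O)NNC(=O)c2cc3ccccc3oc2=O)c(C(=O)c2ccc(Br)cc2)c1` is not yet measured. It differs from compound 2 by bromo in place of hydrogen on an aromatic carbon. Going by the values given here, the only step that bears on this is a 2.0-fold higher number from compound 1 to compound 2 (0.31 log units; beyond the scatter), which shows that a group at this place, para to a large group, went with a lower number than hydrogen. Bromo is not methoxy, so the size of the move is open. For compound 3 a modest move toward a lower number is expected in this assay, a 1.6-fold lower number from compound 2 to compound 3 (0.20 log units; within the scatter). Compound 3 is estimated at 50000 nM, with a range of 20000 nM to 125000 nM.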

Compound 3, half-maximal inhibitory concentration: 87300 nM
Beside the measured number, compound 3's estimate is 1.7-fold (0.24 log units) below it; low and high end bracket the measured number.
By their numbers in this assay, from the lowest: compound 1; then compounds 2 and 3 (each within the scatter of the next).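

In this assay, bromo in place of hydrogen on the aromatic carbon para to a large group gives a 1.1-fold higher number from compound 2 to compound 3 (0.05 log units; within the scatter) and so leaves compound 2 and compound 3 indistinguishable. A group at this place therefore does not in itself go with a lower number, and compound 3 goes against the broader reading that compound 1 first allowed. The replacement of methoxy by bromo gives a 2.3-fold higher number from compound 1 to compound 3 (0.36 log units; beyond the scatter), so among these three compounds only the methoxy compound stands apart, and no measurement in hand accounts for this.

From the compounds shown here alone, whether the separation belongs to methoxy alone remains open, as an ethoxy group, a hydroxyl group or an amine at this place could fall with compound 1 or with compounds 2 and 3. Going by these compounds, a carboxylic acid at this place is equally open, and all three numbers come from a single cell assay.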